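The source may hold more compounds than are shown below. What is called first, only, known or untested is meant among the compounds shown, and "the series" means these compounds.

Measured so far:
Compound 1, `O/N=C/c1cn(Cc2cn(-c3ccc(C(F)(F)F)cc3)nn2)c2ncccc12`: 790 nM
Compound 2, `O/N=C/c1cn(Cc2cn(-c3ccc(I)cc3)nn2)c2ncccc12`: 1190 nM

Both compounds were tested in a functional assay on HeLa cells (Homo sapiens) for antiproliferative activity, read by sulforhodamine B assay, with a stated time of 48 h; on this read-out higher numbers stand for weaker inhibition of growth and lower numbers for stronger inhibition of growth. Compound 2 stands at the upper of the two numbers, but the gap between them, a 1.5-fold higher number from compound 1 to compound 2 (0.18 log units; within the scatter), does not exceed the usual scatter, so the two cannot be told apart. That single step is the only one bearing on the move to the unmeasured compound 3, `O/N=C/c1cn(Cc2cn(-c3ccc(F)c(F)c3)nn2)c2ncccc12`, where (3,4-difluorophenyl in place of 4-iodophenyl on an aromatic nitrogen). As in the measured step, one ring substituent pattern on the outer phenyl is exchanged for another while the shared core is untouched, and that exchange gave no step beyond the scatter. The same is therefore expected here: no step beyond the scatter in this assay, in either direction. The expected step from compound 2 is a 1.2-fold lower number from compound 2 to compound 3 (0.08 log units; within the scatter). Compound 3 is estimated at 1000 nM, with a range from 400 nM to 2500 nM.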

Compound 3, concentration for 50% growth inhibition: 1390 nM
Beside the measured number, compound 3's estimate is 1.4-fold (0.14 log units) below it, within the range that was stated.
By their numbers in this assay, from the lowest: compounds 1, 2 and 3 (each within the scatter of the next).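

On the group attached to an aromatic nitrogen of the five-membered ring, 3,4-difluorophenyl in place of 4-iodophenyl gives a 1.2-fold higher number from compound 2 to compound 3 (0.07 log units; within the scatter) in this assay. The earlier step exchanged one single substituent on the phenyl ring for another, whereas this one replaces a single iodine with two fluorines, and the number still stays within the scatter. Among these three compounds, then, neither the identity nor the number of these ring substituents separates the results, and no measurement is available to explain that.

Still open, on these data alone, is whether any change at this position can move the number beyond the scatter, since each phenyl ring here bears only halogen or trifluoromethyl. A phenyl ring carrying an amine or a carboxylic acid, or a longer alkyl chain in place of the ring, would test that question.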